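A few compounds are considered here, and "the series" means these few. Any claim that something is new, unique, unknown or untested is made for them only; others in the source may bear on it.

In an assay for inhibition of vascular endothelial growth factor receptor 1 (Homo sapiens) (on this read-out higher numbers stand for weaker inhibition and lower numbers for stronger inhibition), compound 1 `Cn1cnc(-c2ccccc2)c1NC(=O)c1ccnc(N)n1` gives no number, only a limit, > 100000 nM. Compound 2 `Cc1nc2sccn2c1/C=C/c1ccnc(N)n1` likewise returns only a limit in this assay, > 100000 nM. For the measured compounds named here, both measured values therefore sit at the limit of > 100000 nM in this assay, at which 2 of the 2 values shown sit, and no step between measured compounds is available. Compound 3 `Nc1nccc(/C=C/c2c(Cl)nc3sccn23)n1` differs from compound 2 by chloro in place of methyl on an aromatic carbon. With both measured compounds at the limit, no step beyond the scatter is expected in either direction. Compound 3 is expected at 150000 nM in this assay, within 30000 nM to 600000 nM, the expected step being a step that the limit leaves unreadable from compound 2 to compound 3.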

Compound 3, half-maximal inhibitory concentration: > 100000 nM
Compound 3 was reported as a limit; the forecaster's own chance of this, stated with the estimate: 85%; the middle value lies beyond the limit too.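

No step can be read between compound 2 and compound 3, as both stand only as limits: the limit of > 100000 nM in this assay, at which 3 of the 3 values shown sit.

The compounds shown leave open how chloro and methyl on this aromatic carbon compare in this assay.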